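Methoxy in place of hydrogen on compound 2

The source may report more compounds than this note shows. Statements on the series, on what has been measured and on what is new or still open speak of the compounds shown alone.

Compound 2 `CN1CCCN(Cc2ccc(-c3ccccc3)cc2)CC1` gives 1480 nM in an assay on isolated protein for inhibition of choline kinase alpha (Homo sapiens), with a stated time of 30 min (on this read-out lower numbers stand for stronger inhibition and higher numbers for weaker inhibition), the highest of the three numbers in hand. Compound 1 `CN1CCCN(Cc2ccc(-c3ccc(CN4CCCN(C)CC4)c(Cl)c3)cc2)CC1` gives 268 nM and compound 3 `CN1CCCN(Cc2ccc(-c3ccc(CN4CCCN(C)CC4)c(F)c3F)cc2)CC1` gives 233 nM; both carry a second substituent on the shared core, and both stand beyond the scatter from compound 2. Among the measured compounds shown here, no two measured compounds differ in only one place, so no single step is on record. Compound 4 `COc1ccc(-c2ccc(CN3CCCN(C)CC3)cc2)cc1` differs from compound 2 by one change: methoxy in place of hydrogen on an aromatic carbon. Nothing in the measured set speaks to this change, so the step from compound 2 to compound 4 is expected to stay within the scatter, a 1.3-fold lower number from compound 2 to compound 4 (0.13 log units; within the scatter). Compound 4 is estimated at 1100 nM, in the range 400 nM to 3000 nM.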

Compound 4, half-maximal inhibitory concentration: 1430 nM
Compound 4: middle estimate off by 1.3-fold (0.11 log units), on the low side, and the stated range covers the measured number.
By their numbers in this assay, from the lowest: compounds 3 and 1 (each within the scatter of the next); then compounds 4 and 2 (each within the scatter of the next).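

In this assay the step is a 1.0-fold lower number from compound 2 to compound 4 (0.01 log units; within the scatter) for methoxy in place of hydrogen on an aromatic carbon, para to a large group. Among the compounds shown here, this is the first single-place comparison, and at this position the added methoxy leaves the number level with that of compound 2. No measurement in hand explains this result. From the compounds shown here alone, whether an amine or a carboxylic acid at this position would also stay within the scatter remains open. So does the outcome for a longer chain, such as ethoxy, at the same carbon.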